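The compounds below may be only part of what the source reports. "The series", "measured", "known", "first", "only" and "open" are said of these compounds alone.

Working notes on the series, toxicity side. Three compounds have been run in a toxicity assay on THP-1 cells (Homo sapiens) for inhibition; a lower number here means that less compound is tolerated, a higher number that more compound is tolerated. Compound 1 (`COc1ccc(-c2cnc(NC(=O)c3ccc(F)cc3)n2Cc2ccccc2)cc1`) reads > 100000 nM, which is a limit of the assay and not a number. Compound 2 (`COc1ccc(-c2cnc(NC(=O)c3ccccc3O)n2C)cc1`) reads > 100000 nM, again a limit. Compound 3 (`Cn1c(-c2ccccc2F)cnc1NC(=O)c1ccc(F)cc1`) reads > 100000 nM, also a limit. Compound 3 therefore has no number of its own and stands level with the other two: the data so far amount to the limit of > 100000 nM in this assay, at which 3 of the 3 values shown sit. Going by the values given here, no measured pair differs in one place, so the series offers no measured step to draw on.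

Compound 4 (`COc1cccc(-c2cnc(NC(=O)c3ccc(F)cc3)n2C)c1`) has 3-methoxyphenyl in place of 2-fluorophenyl on an aromatic carbon. No step beyond the scatter is expected in this assay, and the expected change is a number no higher from compound 3 to compound 4 (the limit leaves the size open). That expectation rests on compound 3, which reads > 100000 nM, a limit. A further limit is the most likely report. For compound 4 the estimated value is 100000 nM, with an expected range of 40000 nM to 100000 nM.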

Compound 4, half-maximal cytotoxic concentration: > 100000 nM
Compound 4: only a limit was reported (the forecaster's own chance of this, stated with the estimate: 85%); the middle value lies on the limit itself.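

Compound 3 and compound 4 both read as limits in this assay, so 3-methoxyphenyl in place of 2-fluorophenyl gives no readable step: the limit of > 100000 nM in this assay, at which 4 of the 4 values shown sit.

The compounds shown leave open whether any change on the shared core would give an actual number in this assay.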